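Isatin oxime cinnamates: a bromo-to-methoxy swap on the benzyl

A few compounds are considered here, and "the series" means these few. Any claim that something is new, unique, unknown or untested is made for them only; others in the source may bear on it.

Measured compounds:
compound 1, `COC(=O)/C=C/c1ccc2c(c1)C(=O)C(=O)N2Cc1ccc2ccccc2c1`, 100 nM
compound 2, `COc1ccc(CN2C(=O)C(=O)c3cc(/C=C/C(=O)N4CCCC4)ccc32)cc1`, 5230 nM
compound 3, `COC(=O)/C=C/c1ccc2c(c1)/C(=N/O)C(=O)N2Cc1ccc(Br)cc1`, 3640 nM

In a functional assay on HT-29 cells (Homo sapiens) for cytotoxicity, read by MTT assay, with a stated time of 48 h (on this read-out higher numbers stand for weaker inhibition and lower numbers for stronger inhibition), compound 1 gives 100 nM, compound 2 gives 5230 nM and compound 3 gives 3640 nM. Compound 3 thus stands second highest of the three numbers: its value and that of compound 2 lie within the usual scatter of each other, whereas compound 1 sits far lower, well beyond that scatter.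

The unmeasured compound 4, `COC(=O)/C=C/c1ccc2c(c1)/C(=N/O)C(=O)N2Cc1ccc(OC)cc1`, differs from compound 3 in one place: methoxy in place of bromo on an aromatic carbon. Among the compounds with values here, no directly comparable pair has been measured, so the size of this step is not known. Compound 2 also carries a 4-methoxybenzyl group and gives 5230 nM, but it differs from compound 4 in other places as well, so it offers only a loose pointer. Compound 4 is expected to give 4500 nM, with a range from 1500 nM to 14000 nM. The estimated step of a 1.2-fold higher number from compound 3 to compound 4 (0.09 log units; within the scatter) is expected to be small, no larger than the scatter, in either direction.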

Compound 4, half-maximal inhibitory concentration: 4940 nM
Compound 4: middle estimate off by 1.1-fold (0.04 log units), on the low side; the measured number falls inside the stated range.
By their numbers in this assay, from the lowest: compound 1; then compounds 3, 4 and 2 (each within the scatter of the next).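

In this assay, within the data shown here, the one pair in this set that differs in a single place gives a 1.4-fold higher number from compound 3 to compound 4 (0.13 log units; within the scatter). Methoxy in place of bromo, on an aromatic carbon para to a large group, therefore brings a second heavy atom and a hydrogen-bond acceptor into this position without a step beyond the scatter, which no earlier comparison could show. No measurement shown here bears on why these two groups read alike.

On these data alone, what an amine, a carboxylic acid or a longer chain would do at this position remains open, as does the reading with a plain hydrogen there. Also open, as far as these compounds go, is whether the same exchange would stay as small on the core of compound 1 or on the core of compound 2.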